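This account rests on a few compounds, and the source may have more. Where it says the series, first, only, none or still open, it means among the compounds named here.

Compound 1 `O=C(Nc1cccc(-n2cc(-c3ccncc3)c(-c3ccc(Cl)c(O)c3)n2)c1)Nc1cccc(C(F)(F)F)c1` is the reference point here. In a functional assay on LOX IMVI cells (Homo sapiens) for inhibition, read by sulforhodamine B assay, with a stated time of 48 h (a lower number here means a stronger inhibitor of growth, a higher number a weaker inhibitor of growth), compound 1 gives 2530 nM, which is the highest of the three numbers recorded so far. Compound 2 `COc1cc(-c2nn(-c3cccc(NC(=O)Nc4cccc(C(F)(F)F)c4)c3)cc2-c2ccncc2)ccc1Cl` gives 789 nM in this assay, and compound 3 `O=C(Nc1cccc(-n2cc(-c3ccncc3)c(-c3ccc(Cl)c(O)c3)n2)c1)Nc1cc(C(F)(F)F)cc(C(F)(F)F)c1` gives 712 nM.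

Two measured steps start from compound 1. The first, a 3.2-fold lower number from compound 1 to compound 2 (0.51 log units; beyond the scatter), comes from a methyl in place of hydrogen on an oxygen on an aromatic ring. The second, a 3.6-fold lower number from compound 1 to compound 3 (0.55 log units; beyond the scatter), comes from a trifluoromethyl in place of hydrogen on an aromatic carbon, on the ring that carries the trifluoromethyl group of the urea. Both changes lower the number beyond the scatter, though only modestly.

Compound 4 `O=C(Nc1cccc(-n2cc(-c3ccncc3)c(-c3ccc(Cl)c(O)c3)n2)c1)Nc1ccc(Cl)c(C(F)(F)F)c1` differs from compound 1 as follows: chloro in place of hydrogen on an aromatic carbon. This change sits on the same ring as the change from compound 1 to compound 3, turning 3-(trifluoromethyl)phenyl into 4-chloro-3-(trifluoromethyl)phenyl. Among the measured compounds shown here, of the two measured steps, the one from compound 1 to compound 3 bears most directly on it, because a 3.6-fold lower number from compound 1 to compound 3 (0.55 log units; beyond the scatter) shows that adding a group to this ring can lower the number. A step of similar, modest size is therefore expected, a 2.5-fold lower number from compound 1 to compound 4 (0.40 log units; beyond the scatter). Compound 4 is estimated to give 1000 nM in this assay, within a range from 400 nM to 2500 nM.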

Compound 4, concentration for 50% growth inhibition: 554 nM
The estimate for compound 4 lay 1.8-fold (0.26 log units) above the measured number; low and high end bracket the measured number.
By their numbers in this assay, from the lowest: compounds 4, 3 and 2 (each within the scatter of the next); then compound 1.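

In this assay, chloro in place of hydrogen on an aromatic carbon, ortho to a trifluoromethyl group and para to a large group, gives a 4.6-fold lower number from compound 1 to compound 4 (0.66 log units; beyond the scatter) and turns 3-(trifluoromethyl)phenyl into 4-chloro-3-(trifluoromethyl)phenyl. The earlier compounds shown here showed a lower number from a change on this ring only with a second trifluoromethyl group, whereas this step shows that a single chlorine atom, a change of one heavy atom with no ring and no net charge, also lowers the number beyond the scatter. No measurement available here accounts for this effect of the chloro group, so the result stands as an observation on growth inhibition alone.

The compounds shown leave open whether a fluoro, a methyl, an amine or a carboxylic acid at this same position would give a lower number than compound 1 as well. They also leave open whether the chloro group on this ring and the methyl on oxygen seen in compound 2 would together lower the number further than either change does alone.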